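Fluoro for methyl on the anilide ring of a dichloroacetamide

The source may report more compounds than this note shows. Statements on the series, on what has been measured and on what is new or still open speak of the compounds shown alone.

The series is built on a dichloroacetyl anilide. Compound 1 `O=C(Nc1ccccc1)C(Cl)Cl` carries no substituent on the aromatic ring, and in a functional assay on A549 cells (Homo sapiens) for antiproliferative activity, read by MTT assay, with a stated time of 72 h (a lower number here means a stronger inhibitor, a higher number a weaker inhibitor), compound 1 gives 130000 nM, a weak result. Compound 2 `Cc1ccccc1NC(=O)C(Cl)Cl` bears a methyl group on the ring, but in this assay compound 2 gives "not determined" (no result reported), so there is no number from which a step to the next compound could be measured. Compound 3 `O=C(Nc1ccccc1F)C(Cl)Cl` is the partner in the comparison: the change from compound 2 to compound 3 is fluoro in place of methyl on an aromatic carbon. Because compound 2 has no value, only the result of compound 1 offers a reference point; a single small exchange on the ring is not expected to move the read-out in this assay far beyond the usual scatter, in either direction. Compound 3 is therefore expected to remain a weak inhibitor, with an estimated value of 150000 nM and a plausible range from 50000 nM to 450000 nM, anchored on the weak result of compound 1 at 130000 nM.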

Compound 3, half-maximal inhibitory concentration: 87500 nM
Estimate against measurement, compound 3: 1.7-fold (0.23 log units) above; the measured number falls inside the stated range.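

Fluoro in place of hydrogen on an aromatic carbon, ortho to a group of 6 heavy atoms, gives in this assay a 1.5-fold lower number from compound 1 to compound 3 (0.17 log units; within the scatter) and so provides the first reading of a substituent at this position, one that cannot be told apart from the unsubstituted compound 1. The exchange of methyl for fluoro itself cannot be read, since compound 2 has no number in this assay and the comparison therefore rests on hydrogen and fluoro alone, leaving the effect of methyl at this position unknown. Nothing given here bears on the reason for this outcome, and the result is recorded without any explanation attached to it.

From the compounds shown here alone, it remains open whether any other group on this aromatic carbon, such as a chlorine, a methoxy group, an amine or a carboxylic acid, would carry the read-out beyond the scatter in either direction. Going by these compounds, it is also open whether a fluoro placed elsewhere on the ring would behave as it does here.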